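Methoxycarbonyl for methylsulfonyl: working notes on the series

A few compounds are considered here, and "the series" means these few. Any claim that something is new, unique, unknown or untested is made for them only; others in the source may bear on it.

Measured in an ADME assay on Caco-2 cells (Homo sapiens) for permeability, tested at 10 uM; on this read-out lower numbers stand for lower permeability and higher numbers for higher permeability:
compound 1 `CC(=O)N1CCN([C@H]2CC[C@H](Nc3ncnc4[nH]cc(C5CCOCC5)c34)CC2)CC1`: 3 10^-6 cm/s
compound 2 `CN(C)C(=O)N1CCN([C@H]2CC[C@H](Nc3ncnc4[nH]cc(C5CCOCC5)c34)CC2)CC1`: 2 10^-6 cm/s
compound 3 `CS(=O)(=O)N1CCN([C@H]2CC[C@H](Nc3ncnc4[nH]cc(C5CCOCC5)c34)CC2)CC1`: 5 10^-6 cm/s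

Compound 3 separates from only one of the other two: the data show a 2.5-fold higher number from compound 2 to compound 3 (0.40 log units; beyond the scatter), against a 1.7-fold higher number from compound 1 to compound 3 (0.22 log units; within the scatter). The next change gives compound 4 `COC(=O)N1CCN([C@H]2CC[C@H](Nc3ncnc4[nH]cc(C5CCOCC5)c34)CC2)CC1`, with methoxycarbonyl in place of methylsulfonyl on an amine nitrogen in a ring. Both steps above bear on this change when read in reverse, since compound 4 has a carbonyl on that nitrogen, as compound 1 and compound 2 do. Also relevant is a 1.5-fold lower number from compound 1 to compound 2 (0.18 log units; within the scatter). A small decrease, not beyond the scatter, is expected, and the estimated step is a 1.4-fold lower number from compound 3 to compound 4 (0.15 log units; within the scatter). For compound 4 the estimated value is 3.5 10^-6 cm/s, with an expected range of 2 10^-6 cm/s to 7 10^-6 cm/s.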

Compound 4, apparent permeability: 20 10^-6 cm/s
The estimate for compound 4 lay 5.7-fold (0.76 log units) below the measured number, outside the stated range (above it).
By their numbers in this assay, from the lowest: compounds 2, 1 and 3 (each within the scatter of the next, the first and the last beyond it); then compound 4.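

In this assay methoxycarbonyl on this amine nitrogen in a ring stands clear of all three earlier groups, with a 4.0-fold higher number from compound 3 to compound 4 (0.60 log units; beyond the scatter) and a 6.7-fold higher number from compound 1 to compound 4 (0.82 log units; beyond the scatter) and a 10-fold higher number from compound 2 to compound 4 (1.00 log units; beyond the scatter) as the steps. A carbonyl on that nitrogen does not by itself set the number, since compound 1 and compound 2 carry one too. Here the group on the carbonyl carbon makes the difference, with methoxy standing apart from methyl and dimethylamino.

Going by these compounds, whether ethoxycarbonyl or a longer alkoxycarbonyl chain would track compound 4 stays open. No supporting data bear on the reason for this result.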